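Series notes: extending the methyl on the shared core

The source may hold more compounds than are shown below. What is called first, only, known or untested is meant among the compounds shown, and "the series" means these compounds.

Of the compounds shown here, three sharing one core have been measured in a functional assay on HepG2 cells (Homo sapiens) for cytotoxicity, read by MTT assay, with a stated time of 48 h; a lower number here means a stronger inhibitor, a higher number a weaker inhibitor. Compound 1 `Cc1nnc(SCc2ccccc2)n1N1C(=O)c2ccccc2C1=O` carries the phenyl on a saturated chain carbon bound to a sulfur. In this assay compound 1 reaches only the limit, > 200000 nM. Compound 2 `CCOC(=O)CSc1nnc(C)n1N1C(=O)c2ccccc2C1=O` has ethoxycarbonyl in place of phenyl at that carbon. Compound 2 likewise gives only the limit, > 200000 nM. Compound 3 `C#CCSc1nnc(C)n1N1C(=O)c2ccccc2C1=O` has ethynyl at the same carbon. Compound 3 also stops at the limit, > 200000 nM. The steps a step that the two limits leave unreadable from compound 1 to compound 2, a step that the two limits leave unreadable from compound 1 to compound 3 and a step that the two limits leave unreadable from compound 2 to compound 3 have no readable size since all three values sit at the limit of > 200000 nM in this assay, at which 3 of the 3 values shown sit.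

Compound 4 `C#CCSc1nnc(CCC)n1N1C(=O)c2ccccc2C1=O` differs from compound 3 by ethyl in place of hydrogen on a saturated chain carbon bound to an aromatic carbon. Going by the values given here, no measured step touches this position; every change so far sits on the saturated chain carbon bound to a sulfur, and all of them stayed unreadable. With compound 3 itself only at a limit, neither direction nor size of the new step can be read from the series. Compound 4 is therefore expected to remain at or near the limit, estimated at 300000 nM with a range from 100000 nM to 1000000 nM. The expected step is a step that the limit leaves unreadable from compound 3 to compound 4, meaning no readable change.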

Compound 4, half-maximal inhibitory concentration: > 200000 nM
Compound 4 ended at the assay's limit; the forecaster's own chance of this, stated with the estimate: 85%; the middle value does not contradict the limit.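

Compound 3 and compound 4 both stop at a limit in this assay, so no step between them can be read: the limit of > 200000 nM in this assay, at which 4 of the 4 values shown sit.

The compounds shown leave open whether any change on either saturated chain carbon gives a readable value in this assay.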